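The source may hold more compounds than are shown below. What is called first, only, known or untested is meant among the compounds shown, and "the series" means these compounds.

Within the data shown here, compound 2 `COc1cc2nc(N3CCN(c4cnccn4)CC3)nc(N)c2cc1OC` gives 0.18 nM in an assay on brain for binding affinity to Adrenergic receptor alpha-1 (Rattus norvegicus) (a lower number here means a stronger inhibitor, a higher number a weaker inhibitor), the lowest of the three numbers so far, though the gap to compound 1 `COc1cc2nc(N3CCN(c4ccncn4)CC3)nc(N)c2cc1OC` at 0.27 nM lies within the scatter; only compound 3 `COc1cc2nc(N3CCN(c4nccc(-c5ccccc5)n4)CC3)nc(N)c2cc1OC`, which carries a bulkier group on the same ring nitrogen and gives 1.66 nM, stands beyond it. The step of a 1.5-fold lower number from compound 1 to compound 2 (0.18 log units; within the scatter) shows that exchanging one two-nitrogen aromatic ring for another at that position changes little. Compound 4 `CCCOc1cc(N2CCN(c3nc(N)c4cc(OC)c(OC)cc4n3)CC2)ncn1` differs from compound 2 by 6-propoxypyrimidin-4-yl in place of pyrazin-2-yl on an amine nitrogen in a ring. Among the measured compounds shown here, no measured step covers a propoxy chain; the only directly bearing step is the small one from compound 1 to compound 2, while compound 3 shows that a larger group at this place goes with a higher number. A modest rise is therefore expected, a 2.8-fold higher number from compound 2 to compound 4 (0.44 log units; beyond the scatter). Compound 4 is estimated at 0.5 nM, range 0.15 nM to 1.8 nM.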

Compound 4, inhibition constant: 0.36 nM
Compound 4: middle estimate off by 1.4-fold (0.14 log units), on the high side; the measured number falls inside the stated range.
By their numbers in this assay, from the lowest: compounds 2, 1 and 4 (each within the scatter of the next); then compound 3.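

In this assay, the steps of a 2.0-fold higher number from compound 2 to compound 4 (0.30 log units; within the scatter) and a 1.3-fold higher number from compound 1 to compound 4 (0.12 log units; within the scatter) show no change that can be read, so propoxy on an aromatic carbon of the pyrimidin-4-yl group is tolerated at this place. A larger group on the amine nitrogen in a ring therefore need not raise the number, and added size alone does not account for compound 3 at 1.66 nM. No data here give a reason for this result.

Open, as far as these compounds go, is whether a longer chain, an amine or a carboxylic acid in place of propoxy would keep the number in this range. Also open, from the compounds shown here alone, is whether propoxy on pyrazin-2-yl would behave alike.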